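A few compounds are considered here, and "the series" means these few. Any claim that something is new, unique, unknown or untested is made for them only; others in the source may bear on it.

Compound 1 `O=C(O)CCC/C=C1\C[C@H]2C[C@@H](O)[C@H](/C=N/OCc3ccc(F)cc3)[C@H]2C1` gives 1900 nM 
Compound 2 `O=C(O)CCC/C=C1\C[C@H]2C[C@@H](O)[C@H](/C=N/OCc3ccccc3)[C@H]2C1` gives 1900 nM 

Among the measured compounds shown here, in a functional assay for agonist activity, with Homo sapiens as the target (on this read-out lower numbers stand for stronger inhibition and higher numbers for weaker inhibition), compound 2 reads 1900 nM and stands level with compound 1, the only other compound measured so far. The next compound, compound 3 `O=C(O)CCC/C=C1\C[C@H]2C[C@@H](O)[C@H](/C=N/OCc3ccc4ccccc4c3)[C@H]2C1`, differs from compound 2 by naphthalen-2-yl in place of phenyl on a saturated chain carbon bound to an oxygen in one place: naphthalen-2-yl in place of phenyl on a saturated chain carbon bound to an oxygen. For the measured compounds named here, the one measured step shows no change at the digits printed from compound 1 to compound 2 (within the scatter) for hydrogen in place of fluoro on an aromatic carbon. Going by the values given here, that is a much smaller exchange, and no measured compound carries a larger aromatic group, so the data indicate no direction for this change. No shift beyond the scatter is therefore expected in this assay, though the uncertainty is wide. The expected step is a 1.3-fold lower number from compound 2 to compound 3 (0.10 log units; within the scatter) and no more than that. For compound 3 the estimated value is 1500 nM with an expected range from 350 nM to 6000 nM.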

Compound 3, half-maximal inhibitory concentration: 1600 nM
Beside the measured number, compound 3's estimate is 1.1-fold (0.03 log units) below it; the measured number falls inside the stated range.
By their numbers in this assay, from the lowest: compounds 3, 1 and 2 (each within the scatter of the next).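

Where the earlier pair tested only hydrogen in place of fluoro on an aromatic carbon, this result enlarges the whole group on a saturated chain carbon bound to an oxygen, and in this assay the change to naphthalen-2-yl from phenyl gives a 1.2-fold lower number from compound 2 to compound 3 (0.07 log units; within the scatter) and the change from 4-fluorophenyl gives a 1.2-fold lower number from compound 1 to compound 3 (0.07 log units; within the scatter) in the same way. Across these three compounds, then, this position accepts a second six-membered aromatic ring with no shift beyond the scatter, although none of them reads stronger than the others. Nothing measured here offers an explanation for this flat result.

On these data alone, whether a non-aromatic group such as cyclohexyl, or a pyridin-3-yl ring, would move the number at this position remains open. So does the effect of an amine on the aromatic ring or a longer chain carrying it.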